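The compounds below may be only part of what the source reports. "The series", "measured", "known", "first", "only" and "open" are said of these compounds alone.

Of the compounds shown here, three built on one shared core have been tested in a functional assay on MCF7 cells (Homo sapiens) for antiproliferative activity, read by MTT assay, with a stated time of 72 h; on this read-out higher numbers stand for weaker inhibition and lower numbers for stronger inhibition. Compound 1 `CCN1CCN(c2cc(C)c3cc(NC(=O)c4ccc[nH]4)ccc3n2)CC1` gives 14700 nM in this assay. Compound 2 `CCN1CCN(c2cc(C)c3cc(NC(=O)c4ccccc4)ccc3n2)CC1` gives 14200 nM in this assay, and compound 3 `CCN1CCN(c2cc(C)c3cc(NC(=O)c4ccccc4Br)ccc3n2)CC1` gives 27500 nM in this assay. Compound 3 has the highest number of the three, yet its steps from compound 1 a 1.9-fold higher number from compound 1 to compound 3 (0.27 log units; within the scatter) and from compound 2 a 1.9-fold higher number from compound 2 to compound 3 (0.29 log units; within the scatter) both stay inside the scatter, so none of the three can be called weaker or stronger than the others. The step of a 1.0-fold lower number from compound 1 to compound 2 (0.02 log units; within the scatter) is likewise flat.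

Compound 4 `CCN1CCN(c2cc(C)c3cc(NC(=O)c4ccc(Cl)c(Cl)c4)ccc3n2)CC1` has not yet been measured. Its change from compound 3 is 3,4-dichlorophenyl in place of 2-bromophenyl on a carbonyl carbon. The step of a 1.9-fold higher number from compound 2 to compound 3 (0.29 log units; within the scatter) bears most closely on this change: there too a halogen entered, bromo in place of hydrogen on an aromatic carbon, and the number stayed inside the scatter. The steps of a 1.0-fold lower number from compound 1 to compound 2 (0.02 log units; within the scatter) and a 1.9-fold higher number from compound 1 to compound 3 (0.27 log units; within the scatter) show that exchanging the whole aromatic group on the carbonyl carbon also moved nothing beyond the scatter. Within the data shown here, with no step here reaching beyond the scatter, no step beyond it is expected in this assay either. Compound 4 is therefore estimated to give 22000 nM, within a range of 8000 nM to 60000 nM, the expected step of a 1.3-fold lower number from compound 3 to compound 4 (0.10 log units; within the scatter) being essentially flat.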

Compound 4, half-maximal inhibitory concentration: 1380 nM
For compound 4 the middle estimate is 16-fold (1.20 log units) above the measured one; the measured number lies below the stated range.
By their numbers in this assay, from the lowest: compound 4; then compounds 2, 1 and 3 (each within the scatter of the next).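

Until now the aromatic group on the carbonyl carbon seemed to make little difference in this assay, but compound 4 shows that this position can respond strongly: the change to 3,4-dichlorophenyl gives a 20-fold lower number from compound 3 to compound 4 (1.30 log units; beyond the scatter), a 10-fold lower number from compound 2 to compound 4 (1.01 log units; beyond the scatter) and an 11-fold lower number from compound 1 to compound 4 (1.03 log units; beyond the scatter). The flat picture therefore held only for 1H-pyrrol-2-yl, phenyl and 2-bromophenyl, and the large steps show that halogen on this phenyl ring does not by itself settle the outcome, since 2-bromophenyl stays within the scatter of phenyl while 3,4-dichlorophenyl goes well beyond it. No supporting measurement is available to explain why this group stands apart from the other three.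

The compounds shown cannot separate the contribution of each chloro group, or say whether chloro is needed rather than another group, so a phenyl ring carrying a single chloro group, or one carrying methoxy groups or a carboxylic acid instead, would be informative. They also leave open whether 3,4-dichlorophenyl keeps this large effect when the ethyl group on the shared core is replaced by a longer chain.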